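The compounds below may be only part of what the source reports. "The series", "measured", "known", "first", "only" and "open" are said of these compounds alone.

Compound 1, `Clc1ccc(C(c2c[nH]c3ccc(Br)cc23)c2c[nH]c3ccc(Br)cc23)cc1`, gives 3500 nM in a functional assay on MCF7 cells (Homo sapiens) for inhibition, read by MTT assay, with a stated time of 48 h; a lower number here means a stronger inhibitor, a higher number a weaker inhibitor.
Compound 2, `Brc1ccc(C(c2c[nH]c3ccc(Br)cc23)c2c[nH]c3ccc(Br)cc23)cc1`, gives 3200 nM in this assay.
Compound 3, `OC[C@H]1O[C@@H](n2cc(C(c3ccc(Cl)cc3)c3cn([C@@H]4O[C@H](CO)[C@@H](O)[C@H](O)[C@H]4O)c4ccc(Br)cc34)c3cc(Br)ccc32)[C@H](O)[C@@H](O)[C@@H]1O`, gives 53200 nM in this assay.

Compounds 1 and 2 share a core and differ in one place: bromo in place of chloro on an aromatic carbon. This change gave a 1.1-fold lower number from compound 1 to compound 2 (0.04 log units; within the scatter), a step that lies within the scatter, so the two values cannot be ordered against each other. Compound 3 carries a different core; how it differs from the core of compound 1 is not broken down here. Its value stands highest of the three, beyond the scatter from compound 1 and from compound 2.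

Compound 4, `OC[C@H]1O[C@@H](n2cc(C(c3ccc(Br)cc3)c3cn([C@@H]4O[C@H](CO)[C@@H](O)[C@H](O)[C@H]4O)c4ccc(Br)cc34)c3cc(Br)ccc32)[C@H](O)[C@@H](O)[C@@H]1O`, has not yet been measured. It differs from compound 3 in one place: bromo in place of chloro on an aromatic carbon. The place is described in the same words for this pair as for the pair of compound 1 and compound 2, so the change is the same one, made on the other core. Because the first instance gave a 1.1-fold lower number from compound 1 to compound 2 (0.04 log units; within the scatter), the expected step in this assay is a 1.1-fold lower number from compound 3 to compound 4 (0.03 log units; within the scatter), a step also within the scatter. This expectation rests on a single measured pair on a different core, and nothing here shows how the change behaves on the core of compound 3. On that basis compound 4 is estimated at 50000 nM, between 22000 nM and 115000 nM.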

Compound 4, half-maximal inhibitory concentration: 51100 nM
The estimate for compound 4 lay 1.0-fold (0.01 log units) below the measured number; the range from low to high includes it.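

In this assay the exchange of chloro for bromo on the aromatic carbon gave a 1.0-fold lower number from compound 3 to compound 4 (0.02 log units; within the scatter) and so, like the earlier exchange, left two values that cannot be ordered against each other. This within-scatter result held on both cores, with no difference between them that can be told apart: the same change on two cores in this assay, a 1.1-fold lower number (0.04 log units; within the scatter) from compound 1 to compound 2 and a 1.0-fold lower number (0.02 log units; within the scatter) from compound 3 to compound 4, 1.1-fold (0.02 log units) apart, within the scatter of two such steps. What carried over, however, is only the absence of a readable step across two pairs; it does not show that a step of readable size would transfer between these cores, and it says nothing about any core beyond the two shown.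

The compounds shown hold only chloro and bromo at this place on the aromatic ring, so it remains open whether a different group there, such as fluoro, methoxy, an amine or a carboxylic acid, would give a step beyond the scatter on either core and, if so, whether that step would be the same on both. Also open, on these data alone, is whether the match between the two cores would hold in a different cell line or at a different stated time.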